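Selenol to Methylsulfanyl on a Fused Bicyclic Core

The compounds below may be only part of what the source reports. "The series", "measured", "known", "first", "only" and "open" are said of these compounds alone.

Measured compounds:
compound 1, `C[Se]c1nc([Se]C)c2cccnc2n1`, in an ADME assay on 184B5 cells (Homo sapiens) for cytotoxicity, read by MTT assay, with a stated time of 72 h; a lower number here means a stronger inhibitor of growth, a higher number a weaker inhibitor of growth: "not determined" (no result reported)
compound 2, `[SeH]c1nc(NCc2ccccc2)c2cccnc2n1`: 3700 nM
compound 3, `CSc1ccc(CNc2nc(SC)nc3ccccc23)cc1`: 22000 nM

Of the two numbers reported, compound 2 stands lowest in this assay with 3700 nM. Among the compounds with values here, compound 3 gives 22000 nM in this assay, a higher number by a margin beyond the usual scatter; no single change links compound 3 to compound 2, so the two values simply stand side by side and carry no step of their own. Compound 1 has no result in this assay and adds nothing to the comparison.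

Compound 4, `CSc1nc(NCc2ccccc2)c2cccnc2n1`, is yet to be measured in this assay. It differs from compound 2 by a group of 2 heavy atoms (1 carbon, 1 sulfur; no ring) in place of one selenium atom, on an aromatic carbon. Within the data shown here, no step between measured compounds covers this change, so any expectation rests on compound 2 alone and on the general picture that compound 3, the only other compound with a number, lies higher. The change is expected to shift the number upward by a modest step, a 2.2-fold higher number from compound 2 to compound 4 (0.33 log units; beyond the scatter), though a result within the scatter of compound 2 would not be surprising. Compound 4 is therefore estimated at 8000 nM, with a range from 2500 nM to 25000 nM.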

Compound 4, concentration for 50% growth inhibition: 49000 nM
Compound 4: the middle estimate sits 6.1-fold (0.79 log units) below what was measured; measured number above the stated range.
By their numbers in this assay, from the lowest: compound 2; then compound 3; then compound 4.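

In this assay, putting methylsulfanyl in place of the single selenium atom, on the aromatic carbon between two ring nitrogen atoms, gives a 13-fold higher number from compound 2 to compound 4 (1.12 log units; beyond the scatter), a large step well beyond the scatter. This is the only pair shown that differs in one place, so it gives the first direct reading at this position: with the rest of the molecule unchanged, the group on this carbon alone moves the growth-inhibition number substantially, and selenium stands on the side of the lower number. Nothing measured here accounts for the size of this step.

The compounds shown leave open whether the step follows the change of element or the added carbon, a question that a thiol or a methylselanyl group on this same carbon would help to separate. Within the data shown here, they also leave open how an amine or a longer chain such as ethylsulfanyl would read at this position, and whether a step of this size would recur with a different group in place of the one that compound 2 and compound 4 share.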